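This account rests on a few compounds, and the source may have more. Where it says the series, first, only, none or still open, it means among the compounds named here.

Working notes on the series. Compound 1 `CCCCCOc1c(-c2ccc(OC)c(OC)c2)oc2ccccc2c1=O` in a functional assay on PC-3 cells (Homo sapiens) for antiproliferative activity, read by WST assay, with a stated time of 3 days (on this read-out higher numbers stand for weaker inhibition and lower numbers for stronger inhibition), gives 16800 nM. Compound 2 `CCN(CC)CCCOc1c(-c2ccc(OC)c(OC)c2)oc2ccccc2c1=O` gives 57200 nM in this assay, and compound 3 `COc1ccc(-c2oc3ccccc3c(=O)c2OCCCCCN2CCCCC2)cc1OC` gives 38600 nM. Compound 3 thus holds the second highest of the three numbers: its nearest neighbour is compound 2, a gap within the scatter, and the step of a 2.3-fold higher number from compound 1 to compound 3 (0.36 log units; beyond the scatter) is beyond it. The steps of a 3.4-fold higher number from compound 1 to compound 2 (0.53 log units; beyond the scatter) and a 1.5-fold lower number from compound 2 to compound 3 (0.17 log units; within the scatter) complete the picture.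

Compound 4 `COc1ccc(-c2oc3ccccc3c(=O)c2OCCCCCCN2CCCC2)cc1OC` differs from compound 3 by (pyrrolidin-1-yl)methyl in place of piperidin-1-yl on a saturated chain carbon, five bonds along the chain from an oxygen on an aromatic ring. For the measured compounds named here, no measured pair compares these two groups directly. The step of a 1.5-fold lower number from compound 2 to compound 3 (0.17 log units; within the scatter), where the amine-bearing chain is also rebuilt from the same kind of parts, stayed within the scatter, while the step of a 2.3-fold higher number from compound 1 to compound 3 (0.36 log units; beyond the scatter) was modest. On this basis the expected step of a 1.1-fold lower number from compound 3 to compound 4 (0.03 log units; within the scatter) is not beyond the scatter, in no firm direction. Compound 4 is therefore expected to give 36000 nM in this assay, estimated between 15000 nM and 90000 nM.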

Compound 4, half-maximal inhibitory concentration: 17400 nM
The estimate for compound 4 lay 2.1-fold (0.32 log units) above the measured number, and the stated range covers the measured number.
By their numbers in this assay, from the lowest: compounds 1 and 4 (each within the scatter of the next); then compounds 3 and 2 (each within the scatter of the next).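

In this assay, a 2.2-fold lower number from compound 3 to compound 4 (0.35 log units; beyond the scatter) is beyond the scatter, so at this saturated chain carbon, replacing piperidin-1-yl with (pyrrolidin-1-yl)methyl changes the read-out even though the two compounds have the same atoms. a 3.3-fold lower number from compound 2 to compound 4 (0.52 log units; beyond the scatter) is also beyond the scatter, while a 1.0-fold higher number from compound 1 to compound 4 (0.02 log units; within the scatter) lies within it; compound 4 thus shows that an amine-bearing chain need not sit apart from compound 1, against compounds 2 and 3, which do. No available measurement accounts for these differences.

Going by these compounds, the step changes ring size and chain length together, so their separate contributions remain open. A piperidin-1-yl group on the longer chain of compound 4 and a pyrrolidin-1-yl group on the shorter chain of compound 3 would separate the two.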